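Losing one methoxy from the dimethoxyphenyl arm of compound 1

The source may report more compounds than this note shows. Statements on the series, on what has been measured and on what is new or still open speak of the compounds shown alone.

Compound 1 `COc1ccc(CNc2nc3cc(N)cc(N)c3nc2-c2ccccc2)cc1OC` carries a benzyl amine bearing two methoxy groups on the shared core. In a functional assay on MCF7 cells (Homo sapiens) for inhibition, read by sulforhodamine B assay, with a stated time of 48 h (on this read-out higher numbers stand for weaker inhibition of growth and lower numbers for stronger inhibition of growth), compound 1 reaches only a limit, < 100000 nM. Compound 3 `COc1cc(CNc2nc3cc(N)cc(N)c3nc2-c2ccccc2)cc(OC)c1OC`, with a third methoxy, likewise gives only a limit in this assay, < 50200 nM, so the step that the two limits leave unreadable from compound 1 to compound 3 cannot be sized. Compound 2 `CCOC(=O)[C@H](CCC(=O)O)NC(=O)c1ccc(Sc2nc3cc(N)cc(N)c3nc2-c2ccccc2)cc1`, a different arm on the same core, also stops at a limit in this assay, < 100000 nM. The evidence thus consists of the limit of < 100000 nM in this assay, at which 2 of the 3 values shown sit, and (the limit of < 50200 nM in this assay, at which 1 of the 3 values shown sits), neither of which fixes a number for compound 1.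

Compound 4 `COc1ccc(CNc2nc3cc(N)cc(N)c3nc2-c2ccccc2)cc1` differs from compound 1 by hydrogen in place of methoxy on an aromatic carbon, ortho to a methoxy group and meta to a large group. Among the compounds with values here, since no measured step here is readable, there is no basis for expecting a change in this assay beyond the scatter. Compound 4 is therefore estimated to sit near 40000 nM, within 5000 nM to 100000 nM, a step that the limit leaves unreadable from compound 1 to compound 4 that is expected to be negligible.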

Compound 4, concentration for total growth inhibition: 26300 nM
Beside the measured number, compound 4's estimate is 1.5-fold (0.18 log units) above it, within the range that was stated.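

Compound 1 stands only as a limit in this assay, so the step to compound 4 cannot be read, even though compound 4 has a measured value. The compounds shown leave open whether going from 3,4-dimethoxyphenyl to 4-methoxyphenyl changes growth inhibition at all, and by how much.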